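The compounds below may be only part of what the source reports. "The series", "measured", "known", "first", "only" and "open" are said of these compounds alone.

Three compounds share one core and differ only in the group on the aryl ring. Compound 1 `COc1ccc(CN2C(=O)C(=O)c3cc(-c4ccc(OC)cc4)ccc32)cc1` gives 30 nM in a functional assay on K562 cells (Homo sapiens) for antiproliferative activity, read by MTT assay, with a stated time of 48 h; a higher number here means a weaker inhibitor, a lower number a stronger inhibitor. Compound 2 `COc1ccc(CN2C(=O)C(=O)c3cc(-c4ccc(Cl)cc4)ccc32)cc1` gives 230 nM, and compound 3 `COc1ccc(CN2C(=O)C(=O)c3cc(-c4ccc(C#N)cc4)ccc32)cc1` gives 260 nM; these two lie within the scatter of each other, as a 1.1-fold higher number from compound 2 to compound 3 (0.05 log units; within the scatter) shows, while both sit well above compound 1, by a 7.7-fold higher number from compound 1 to compound 2 (0.88 log units; beyond the scatter) and an 8.7-fold higher number from compound 1 to compound 3 (0.94 log units; beyond the scatter). Compound 4 `COc1ccc(CN2C(=O)C(=O)c3cc(-c4ccc5ccccc5c4)ccc32)cc1` carries naphthalen-2-yl in place of 4-cyanophenyl on an aromatic carbon. For the measured compounds named here, no measured step swaps a single substituent for a second fused ring, so the measured steps only mark the range so far. Compound 3's value is expected to change little, with the estimate for compound 4 being 150 nM, between 40 nM and 600 nM, a step of a 1.7-fold lower number from compound 3 to compound 4 (0.24 log units; within the scatter).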

Compound 4, half-maximal inhibitory concentration: 340 nM
For compound 4 the middle estimate is 2.3-fold (0.36 log units) below the measured one; the measured number falls inside the stated range.
By their numbers in this assay, from the lowest: compound 1; then compounds 2, 3 and 4 (each within the scatter of the next).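

Swapping the single substituted ring at this position for a second fused ring leaves the number in the same range as the chloro and cyano compounds in this assay, with a 1.3-fold higher number from compound 3 to compound 4 (0.12 log units; within the scatter) and a 1.5-fold higher number from compound 2 to compound 4 (0.17 log units; within the scatter). Compound 1 remains the only one apart from the rest, with an 11-fold higher number from compound 1 to compound 4 (1.05 log units; beyond the scatter). Nothing shown here explains why the 4-methoxyphenyl compound differs from the other three.

As far as these compounds go, whether a 4-ethoxyphenyl group, with its longer chain, would give a number nearer compound 1 or nearer the other three remains open. So does the result for a 4-aminophenyl or a 4-carboxyphenyl group at this position.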